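The source may report more compounds than this note shows. Statements on the series, on what has been measured and on what is new or still open speak of the compounds shown alone.

Working notes on the series. In a functional assay on SMMC-7721 cells (Homo sapiens) for cytotoxicity, read by MTT assay, with a stated time of 24 h (on this read-out lower numbers stand for stronger inhibition and higher numbers for weaker inhibition), compound 1 `COc1cc(/C=C2\CN(S(=O)(=O)c3ccc(F)cc3)C/C(=C\c3cc(OC)c(OC)c(OC)c3)C2=O)cc(OC)c1OC` gives 3840 nM and compound 2 `COc1cc(/C=C2\CN(S(=O)(=O)c3ccc(F)cc3)C/C(=C\c3cccc([N+](=O)[O-])c3)C2=O)cc(OC)c1OC` gives 4900 nM while compound 3 `COc1cc(/C=C2\CN(S(=O)(=O)c3ccc(F)cc3)C/C(=C\c3cc(OC)c(OC)c(OC)c3)C2=O)cc(OC)c1` gives 5420 nM on the same read-out. Compound 2 therefore does not separate from the other two: the steps are a 1.3-fold higher number from compound 1 to compound 2 (0.11 log units; within the scatter) and a 1.1-fold higher number from compound 2 to compound 3 (0.04 log units; within the scatter) and also a 1.4-fold higher number from compound 1 to compound 3 (0.15 log units; within the scatter) with all three inside the scatter.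

The next case is compound 4 `COc1cc(/C=C2\CN(S(=O)(=O)c3ccc(NC(C)=O)cc3)C/C(=C\c3cccc([N+](=O)[O-])c3)C2=O)cc(OC)c1OC` with acetamido in place of fluoro on an aromatic carbon so that 4-fluorophenyl becomes 4-acetamidophenyl. For the measured compounds named here, none of the measured steps reaches this place. The 4-fluorophenyl is common to compound 1, compound 2 and compound 3, and their steps concern only the aromatic groups on the double-bonded chain carbons. The data thus hold no direct measure of this change. Going by the values given here, the only indirect guide is that the changes made elsewhere stayed small, as with a 1.4-fold higher number from compound 1 to compound 3 (0.15 log units; within the scatter) in the same assay. No step beyond the scatter is expected in this assay in either direction, but the range must stay wide for an untested place. The expected step is a 1.0-fold higher number from compound 2 to compound 4 (0.01 log units; within the scatter) on this estimate. For compound 4 the estimated value is 5000 nM with an expected range from 1800 nM to 14000 nM in this assay.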

Compound 4, half-maximal inhibitory concentration: 1950 nM
Compound 4: the middle estimate sits 2.6-fold (0.41 log units) above what was measured; low and high end bracket the measured number.
By their numbers in this assay, from the lowest: compounds 4, 1, 2 and 3 (each within the scatter of the next, the first and the last beyond it).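

Going from 4-fluorophenyl to 4-acetamidophenyl in this assay gives a 2.5-fold lower number from compound 2 to compound 4 (0.40 log units; beyond the scatter) and is the only step in the series so far that lies beyond the scatter, though it is modest in size. This shows that the aromatic carbon carrying fluoro in compounds 1, 2 and 3, a place their own steps never touched, can shift the read-out, whereas the exchanges among the aromatic groups on the double-bonded chain carbons stayed within the scatter. This reading rests on one pair only, and no measurement available here explains why acetamido gives the lower number.

The compounds shown leave open whether an amine, a carboxylic acid or a longer acyl chain such as propanamido on this aromatic carbon would shift the number in the same direction as acetamido, and so whether the whole acetamido group matters or only part of it. From the compounds shown here alone, it also remains open whether the same exchange would give a similar step with the 3,4,5-trimethoxyphenyl group of compound 1 in place of the 3-nitrophenyl group of compound 2.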